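Primary Amide to Methylamide on a Shared Core

The source may report more compounds than this note shows. Statements on the series, on what has been measured and on what is new or still open speak of the compounds shown alone.

The series rests on a shared core carrying an acetic acid side chain in compound 1 `COc1cc2c(cc1OC)C(CC(=O)O)CC2` and the corresponding primary amide in compound 2 `COc1cc2c(cc1OC)C(CC(N)=O)CC2`. In a functional assay on the whole organism (strain Wistar) for inhibition, with Rattus norvegicus as the target, read by paw edema, with stated times of 60 min and 3 h, at a dose of 100 mg/kg by the oral route (on this read-out lower numbers stand for less inhibition and higher numbers for more inhibition at the one dose given (going by the name of the read-out)), compound 1 gives 27.5%, and compound 2 gives 30.4%. Among the measured compounds shown here, the only step measured so far, a number 2.9 percentage points higher from compound 1 to compound 2 (within the scatter), turns the carboxylic acid into the amide. Compound 2 stands highest of the two numbers, but its nearest neighbour, compound 1, lies only within the scatter of it, so the two numbers count as level.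

Compound 3 `CNC(=O)CC1CCc2cc(OC)c(OC)cc21` carries the change (methyl in place of hydrogen on an amide-type nitrogen). For the measured compounds named here, no measured step alters the amide nitrogen itself; the one step that touches the carbonyl region, a number 2.9 percentage points higher from compound 1 to compound 2 (within the scatter), stayed within the scatter, and that is the only guide at hand. On this basis the change a number 0.4 percentage points lower from compound 2 to compound 3 (within the scatter) is expected to stay within the scatter. Compound 3 is therefore estimated to give 30% in this assay, with a range from 15% to 45%.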

Compound 3, a percentage reported as inhibition, in the whole organism at one dose (the size of the read-out at that dose, not a potency): 29%
Beside the measured number, compound 3's estimate is 1 percentage points above it, within the range that was stated.
By their numbers in this assay, from the lowest: compounds 1, 3 and 2 (each within the scatter of the next).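

Among the compounds shown here, the amide nitrogen itself is now touched for the first time: in this assay, methyl in place of hydrogen on this amide-type nitrogen gives a number 1.4 percentage points lower from compound 2 to compound 3 (within the scatter), so this position accepts a methyl group with no change that can be told from the scatter at the one dose given. Set against the carboxylic acid, methylamino in place of hydroxy on a carbonyl carbon gives a number 1.5 percentage points higher from compound 1 to compound 3 (within the scatter), so the acid, the primary amide and the methylamide all read as level, and neither the change at the carbonyl carbon nor the one on the nitrogen has yet moved the read-out. Nothing on hand offers an explanation for these numbers.

On these data alone, whether an ethyl group, a phenyl group or a second methyl on that nitrogen would move the number beyond the scatter stays open, as does the effect of a longer chain in place of the acetic acid side chain. With a single dose behind each number, the compounds shown also say nothing about potency, and they leave open whether an amine in place of the amide would read differently.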